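Adding a Methoxy to the Core of Compound 2

The source may report more compounds than this note shows. Statements on the series, on what has been measured and on what is new or still open speak of the compounds shown alone.

Compound 2 `COc1ccc2c(=O)cc(/C=C/[S+](C)[O-])oc2c1` is the reference point of this comparison. Going by the values given here, in a functional assay on A549 cells (Homo sapiens) for inhibition, with a stated time of 48 h (a lower number here means a stronger inhibitor, a higher number a weaker inhibitor), compound 2 gives 10500 nM, and this is the only number that appears among the three compounds measured so far. Compound 1 `COc1ccc2c(=O)cc(/C=C/[S+](C)[O-])oc2c1OC` reaches only a limit, > 10000 nM. Compound 3 `COc1ccc2c(=O)cc(/C=C/[S+](C)[O-])oc2c1O` likewise sits at a limit, > 10000 nM. Because of the limit of > 10000 nM in this assay, at which 2 of the 3 values shown sit, none of the three steps among these compounds can be read: a step that the limit leaves unreadable from compound 1 to compound 2, a step that the two limits leave unreadable from compound 1 to compound 3 and a step that the limit leaves unreadable from compound 2 to compound 3.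

Compound 4 `COc1cc2oc(/C=C/[S+](C)[O-])cc(=O)c2cc1OC` is not yet measured. It differs from compound 2 as methoxy in place of hydrogen on an aromatic carbon. Among the compounds with values here, the measured steps that bear on this change are the one from compound 1 to compound 2 and the one from compound 2 to compound 3, and both are unreadable, so they set neither a direction nor a size. Compound 4 is therefore expected to show a 1.1-fold lower number from compound 2 to compound 4 (0.02 log units; within the scatter), a step within the usual scatter. In this assay compound 4 is estimated at 10000 nM, with a range from 4000 nM to 25000 nM, and there is a real chance that only a limit is reported.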

Compound 4, half-maximal inhibitory concentration: > 10000 nM
Compound 4 gave a limit, no number; the forecaster's own chance of this, stated with the estimate: 50%; the middle value sits exactly at the limit.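

Compound 4 reaches only a limit in this assay, > 10000 nM. No new step can be read between compound 2 and compound 4 because of this limit: the limit of > 10000 nM in this assay, at which 3 of the 4 values shown sit.

The compounds shown leave open whether methoxy in place of hydrogen on this aromatic carbon changes the number of compound 2 at all, and in which direction.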